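Swapping the N-aryl group on a shared core

This account rests on a few compounds, and the source may have more. Where it says the series, first, only, none or still open, it means among the compounds named here.

Compound 1 `O=C(Nc1ccc(Oc2ccnc3[nH]ccc23)c(F)c1)c1cc2cccnc2n(-c2ccc(Br)cc2F)c1=O`: 820 nM
Compound 2 `Cn1ccc2c(Oc3ccc(NC(=O)c4cc5cccnc5n(-c5ccc(Br)cc5F)c4=O)cc3)ccnc21`: 2580 nM
Compound 3 `COc1ccc(-n2c(=O)c(C(=O)Nc3ccc(Oc4ccnc5c4ccn5C)c(F)c3)cc3cccnc32)cc1`: 1290 nM

Of the compounds shown here, three built on one shared core have been measured in a functional assay on HT-29 cells (Homo sapiens) for antiproliferative activity, read by MTT assay, with a stated time of 72 h; on this read-out higher numbers stand for weaker inhibition and lower numbers for stronger inhibition. Compound 1 gives 820 nM in this assay, compound 2 gives 2580 nM, and compound 3 gives 1290 nM. Compound 3 stands second highest of the three numbers; its nearest neighbour is compound 1, whose number is lower by an amount within the scatter, and its furthest is compound 2, whose number is higher by an amount that also stays within the scatter. Taken together, the three values show no separation that repeated measurements could not produce.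

Compound 4 `Cn1ccc2c(Oc3ccc(NC(=O)c4cc5cccnc5n(-c5ccc(Br)cc5F)c4=O)cc3F)ccnc21` has not yet been measured in this assay. It differs from compound 3 in one place: 4-bromo-2-fluorophenyl in place of 4-methoxyphenyl on an aromatic nitrogen. For the measured compounds named here, no pair among the measured compounds differs in exactly this way, so no measured step guides the expectation directly. Compound 1 and compound 2 both carry the same 4-bromo-2-fluorophenyl group that enters here, and their values bracket that of compound 3 without clearing the scatter. Compound 4 is therefore expected to land near compound 3, with a step of a 1.2-fold lower number from compound 3 to compound 4 (0.07 log units; within the scatter) that is not expected to exceed the scatter in either direction. The estimate for compound 4 in this assay is 1100 nM, with a range from 450 nM to 2800 nM.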

Compound 4, half-maximal inhibitory concentration: 3290 nM
Beside the measured number, compound 4's estimate is 3.0-fold (0.48 log units) below it, and the stated range ends below it.
By their numbers in this assay, from the lowest: compounds 1, 3, 2 and 4 (each within the scatter of the next, the first and the last beyond it).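

The exchange on the aromatic nitrogen can now be read directly: in this assay, 4-bromo-2-fluorophenyl in place of 4-methoxyphenyl gives a 2.6-fold higher number from compound 3 to compound 4 (0.41 log units; beyond the scatter), so this position responds modestly to the group it carries. On the same side of the molecule, fluoro in place of hydrogen on an aromatic carbon gives a 1.3-fold higher number from compound 2 to compound 4 (0.11 log units; within the scatter), which does not separate the two compounds, whereas methyl in place of hydrogen on an aromatic nitrogen gives a 4.0-fold higher number from compound 1 to compound 4 (0.60 log units; beyond the scatter), so that methyl also counts modestly. Nothing in the data shown accounts for either modest step.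

The compounds shown leave open whether the bromo or the fluoro group carries the step at the first position, as the two enter together. Going by these compounds, how a plain phenyl, a 4-chlorophenyl or a pyridyl group would read there also remains open.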